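The compounds below may be only part of what the source reports. "The series", "measured", "known", "first", "only" and "open" are said of these compounds alone.

Within the data shown here, in an ADME assay on microsomes from liver (Homo sapiens) for metabolic stability, read by LC-MS, with a stated time of 30 min, tested at 1 uM (a lower number here means that less of the compound is left, a higher number that more of the compound is left), compound 1 (`O=C(NCc1ccc(S(=O)(=O)c2cccc(C(F)(F)F)c2)cc1)c1cc2cnccc2[nH]1`) gives 81% and compound 2 (`O=C(NCc1ccc(S(=O)(=O)c2cccc(C(F)(F)F)c2)cc1)c1cnc2nccn2c1`) gives 41%, the lower of the two numbers so far. Compound 3 (`O=C(NCc1ccc(S(=O)(=O)c2cccc(C(F)(F)F)c2)cc1)c1cc2ccncc2s1`) differs from compound 2 on the carbonyl carbon: a group of 9 heavy atoms (7 carbon, 1 nitrogen, 1 sulfur; one five-membered aromatic ring with 1 hetero atom, one six-membered aromatic ring with 1 hetero atom) in place of a group of 9 heavy atoms (6 carbon, 3 nitrogen; one five-membered aromatic ring with 2 hetero atoms, one six-membered aromatic ring with 2 hetero atoms), on a carbonyl carbon. Among the measured compounds shown here, the one measured step bearing on this is a number 40 percentage points lower from compound 1 to compound 2 (beyond the scatter), which is large and went towards the group with more hetero atoms. Compound 3 has one hetero atom in each ring, as compound 1 does, but its group is not the same. A partial recovery is therefore expected, with an estimated step of a number 21 percentage points higher from compound 2 to compound 3 (beyond the scatter) in this assay. For compound 3 the estimate is 62%, with an expected range of 38% to 85%.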

Compound 3, percent of the compound remaining: 43%
Compound 3: the middle estimate sits 19 percentage points above what was measured; the range from low to high includes it.
By their numbers in this assay, from the lowest: compounds 2 and 3 (each within the scatter of the next); then compound 1.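

In this assay the swap on the carbonyl carbon gives a number 2 percentage points higher from compound 2 to compound 3 (within the scatter), so the count of hetero atoms per ring does not sort these groups: compound 3 shares that count with compound 1 yet stays level with compound 2. Replacing the group of compound 1 gives a number 38 percentage points lower from compound 1 to compound 3 (beyond the scatter), so matching ring sizes and that count do not keep the higher number. Nothing available explains this difference.

Still open, on these data alone, is whether a methyl or an amine on the group attached to the carbonyl carbon would move the number in either direction.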